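Rearranging the Amide Tail: Cytotoxicity from Compound 2 to Compound 4

The source may report more compounds than this note shows. Statements on the series, on what has been measured and on what is new or still open speak of the compounds shown alone.

Compound 1, `CCCC(=O)OCSc1ccc(OC)cc1C(=O)NCCC(N)=O`, gives > 100 uM in an ADME assay on CEM-SS cells (Homo sapiens) for cytotoxicity, read by XTT assay, with a stated time of 6 days; a lower number here means that less compound is tolerated, a higher number that more compound is tolerated; this is a limit of the assay rather than a number.
Compound 2, `CCCC(=O)OCSc1ccccc1C(=O)NCCCCCC(N)=O`, gives 16.3 uM in this assay.
Compound 3, `CCCC(=O)OCSc1ccccc1C(=O)Nc1ccc(C(N)=O)cc1`, gives 39 uM in this assay.

Compound 2 stands at the lowest of the two numbers shown, so it is the compound that cells tolerate least among those with a measured number; compound 3 sits at a higher number, and the gap between compound 2 and compound 3 is beyond the scatter. One further value sits at the limit, as the limit of > 100 uM in this assay, at which 1 of the 3 values shown sits, records.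

The unmeasured compound 4, `CCCC(=O)OCSc1ccccc1C(=O)NCC(=O)NC(C)(C)C`, is built from the same atoms as compound 2, joined differently. The change is (tert-butyl)carbamoyl in place of 4-carbamoylbutyl on a saturated chain carbon bound to an amide-type nitrogen.

For the measured compounds named here, no measured pair shows this change, so its size can only be guessed. The branched tail is expected to move the number modestly upward, a step of about a 1.8-fold higher number from compound 2 to compound 4 (0.26 log units; within the scatter), roughly at the edge of the scatter. Compound 4 is therefore estimated at 30 uM, with a range from 10 uM to 100 uM.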

Compound 4, half-maximal toxic concentration: 46.8 uM
For compound 4 the middle estimate is 1.6-fold (0.19 log units) below the measured one; low and high end bracket the measured number.
By their numbers in this assay, from the lowest: compound 2; then compounds 3 and 4 (each within the scatter of the next). At a limit, above all of these: compound 1.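

Rearranging the atoms of the tail, with none added or removed, is enough to change the reading in this assay, giving a 2.9-fold higher number from compound 2 to compound 4 (0.46 log units; beyond the scatter). For the compounds shown here, this is the first measured pair that differs in one place, and it shows that 4-carbamoylbutyl and (tert-butyl)carbamoyl, with the same heavy atoms and the same counts of hydrogen-bond donors and acceptors, are not interchangeable on a saturated chain carbon bound to an amide-type nitrogen. Nothing measured here bears on why the step occurs.

As far as these compounds go, it remains open whether a tail ending in an amine or a carboxylic acid, rather than an amide, would give a higher or a lower number in this assay. A single pair also cannot say whether the same rearrangement would give a similar step on a longer chain or on the core of compound 1.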